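The compounds below may be only part of what the source reports. "The series", "measured", "known", "first", "only" and "open" are said of these compounds alone.

In an ADME assay on Vero cells (Chlorocebus sabaeus) for cytotoxicity, read by CellTiter-Glo, with a stated time of 72 h (on this read-out lower numbers stand for higher toxicity in this test and higher numbers for lower toxicity in this test), compound 3 `Cc1cccc2c1[n+]([O-])c(NC1CCC1)n[n+]2[O-]` gives 22 ug/mL, level with compound 2 `CCNc1n[n+]([O-])c2cccc(C)c2[n+]1[O-]` at 22 ug/mL. Together they hold the highest number of the three, while compound 1 `[O-][n+]1nc(NC2CCCC2)[n+]([O-])c2ccccc21` sits lower at 10 ug/mL. That gap lies beyond the scatter. Next comes compound 4 `Cc1cccc2c1[n+]([O-])c(NC1CCCC1)n[n+]2[O-]`, with cyclopentyl in place of cyclobutyl on a nitrogen on an aromatic ring. Within the data shown here, the one measured step at this place, no change at the digits printed from compound 2 to compound 3 (within the scatter), stayed within the scatter. Compound 1 also carries cyclopentylamino, on its own core, and at 10 ug/mL it leaves room for a slightly lower number. The expected change is a 1.2-fold lower number from compound 3 to compound 4 (0.09 log units; within the scatter), not beyond the scatter. For compound 4 the estimated value is 18 ug/mL, with an expected range of 9 ug/mL to 36 ug/mL.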

Compound 4, half-maximal cytotoxic concentration: 3.7 ug/mL
The estimate for compound 4 lay 4.9-fold (0.69 log units) above the measured number, outside the stated range (below it).
By their numbers in this assay, from the lowest: compound 4; then compound 1; then compounds 2 and 3 (each within the scatter of the next).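

In this assay, cyclopentyl in place of cyclobutyl on a nitrogen on an aromatic ring gives a 5.9-fold lower number from compound 3 to compound 4 (0.77 log units; beyond the scatter), and cyclopentyl in place of ethyl gives a 5.9-fold lower number from compound 2 to compound 4 (0.77 log units; beyond the scatter), so this position is not indifferent to its group, as no change at the digits printed from compound 2 to compound 3 (within the scatter) alone had suggested. With cyclopentylamino held constant, methyl in place of hydrogen on an aromatic carbon gives a 2.7-fold lower number from compound 1 to compound 4 (0.43 log units; beyond the scatter), so the methyl also counts. Nothing available explains either step.

As far as these compounds go, whether the lower number is particular to cyclopentyl remains open: cyclohexyl or an open chain such as isopropyl would test this. A hydroxyl on the cyclopentyl ring is also untested here.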